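Fluorine for Bromine on a Pair at the Limit

This account rests on a few compounds, and the source may have more. Where it says the series, first, only, none or still open, it means among the compounds named here.

Compound 1 `N#Cc1ccc(-c2cc(COC(Cc3cn(C4CCN(Cc5ccc([N+](=O)[O-])cc5)CC4)nn3)c3ccc(Br)cc3)on2)cc1` and compound 2 `O=[N+]([O-])c1ccc(CN2CCC(n3cc(CC(OCc4cc(-c5cccc(Br)c5)no4)c4ccc(Br)cc4)nn3)CC2)cc1` share one core and were both tested in a functional assay on MDA-MB-231 cells (Homo sapiens) for cytotoxicity, with a stated time of 48 h; on this read-out higher numbers stand for weaker inhibition and lower numbers for stronger inhibition. In this assay compound 1 gives only a limit, > 25000 nM. In this assay compound 2 also gives only a limit, > 25000 nM. The step that the two limits leave unreadable from compound 1 to compound 2 stays unreadable because both values sit at the limit of > 25000 nM in this assay, at which 2 of the 2 values shown sit. Compound 3 `O=[N+]([O-])c1ccc(CN2CCC(n3cc(CC(OCc4cc(-c5cccc(F)c5)no4)c4ccc(Br)cc4)nn3)CC2)cc1` differs from compound 2 by fluoro in place of bromo on an aromatic carbon. For the measured compounds named here, no measured step bears on this change, so the expected step that the limit leaves unreadable from compound 2 to compound 3 in this assay is nothing beyond the scatter. Compound 3 is therefore estimated at 30000 nM, between 8000 nM and 120000 nM, most likely again only a limit.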

Compound 3, half-maximal inhibitory concentration: 5000 nM
For compound 3 the middle estimate is 6.0-fold (0.78 log units) above the measured one, and the stated range ends above it.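

In this assay, fluoro in place of bromo on this aromatic carbon gives an at least 5.0-fold lower number from compound 2 to compound 3 (0.69 log units; beyond the scatter), and 3-fluorophenyl in place of 4-cyanophenyl gives an at least 5.0-fold lower number from compound 1 to compound 3 (0.69 log units; beyond the scatter). For the compounds shown here, compound 3 is thus the first compound here with a real number, which shows that the group on this ring can change the read-out, and both steps are minimum sizes since one end of each is a limit. The earlier step cannot be read, and the limit shared by the other two compounds is a ceiling, not a number: the limit of > 25000 nM in this assay, at which 2 of the 3 values shown sit.

From the compounds shown here alone, whether a chloro group, a methoxy group or plain hydrogen at this place would give a number or another limit stays open. So does how much stronger compound 3 really is than either compound at the limit.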